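This account rests on a few compounds, and the source may have more. Where it says the series, first, only, none or still open, it means among the compounds named here.

Working notes on the hydroxamic acid series in an assay on Sf9 cells for inhibition of protein deacetylase HDAC6 (Homo sapiens), read by fluorescence, with a stated time of 40 min; on this read-out higher numbers stand for weaker inhibition and lower numbers for stronger inhibition.

Compound 1 `COc1ccc(-c2nc(CNc3ccc(C(=O)NO)cc3)n(-c3ccccc3)n2)cc1` gives 163 nM in this assay. Among the compounds with values here, its only measured neighbour is compound 2 `O=C(NO)c1ccc(NCc2nc(-c3cccc(Cl)c3)nn2-c2ccccc2)cc1`, which in this assay gives 115 nM; the change between them, 3-chlorophenyl in place of 4-methoxyphenyl on an aromatic carbon, amounts to a 1.4-fold lower number from compound 1 to compound 2 (0.15 log units; within the scatter), so the two compounds stand together within the scatter and no order between them can be read.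

Compound 3 `O=C(NO)c1ccc(NCc2nc(-c3ccccc3)nn2-c2ccccc2)cc1` has not yet been measured in this assay. It differs from compound 1 by hydrogen in place of methoxy on an aromatic carbon. Within the data shown here, the single step on record that bears on the same aryl group is the swap from compound 1 to compound 2, which stayed within the scatter, and so a similarly small step is expected here: no change beyond the scatter, a 1.0-fold lower number from compound 1 to compound 3 (0.01 log units; within the scatter), in either direction. Compound 3 is therefore estimated at 160 nM, with a range from 60 nM to 420 nM.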

Compound 3, half-maximal inhibitory concentration: 112 nM
Compound 3: the middle estimate sits 1.4-fold (0.15 log units) above what was measured, and the stated range covers the measured number.
By their numbers in this assay, from the lowest: compounds 3, 2 and 1 (each within the scatter of the next).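

Hydrogen in place of methoxy (a 1.5-fold lower number from compound 1 to compound 3 (0.16 log units; within the scatter)) and hydrogen in place of chloro (a 1.0-fold lower number from compound 2 to compound 3 (0.01 log units; within the scatter)) both stay within the scatter. The earlier step only exchanged one substituent for another, whereas compound 3 adds the bare phenyl and shows that, among these three compounds, neither methoxy nor chloro on the aryl group separates from the unsubstituted case. No measurement at hand gives any reason for these numbers standing together.

As far as these compounds go, whether a carboxylic acid or a primary amine on this aryl group would also stay within the scatter remains open, as the three compounds carry only hydrogen, chloro and methoxy there. Also open, from the compounds shown here alone, is how far the number would move with a change elsewhere on the shared core, such as a longer chain in the link to the hydroxamic acid.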